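A few compounds are considered here, and "the series" means these few. Any claim that something is new, unique, unknown or untested is made for them only; others in the source may bear on it.

Measured so far:
compound 1 `CN1CCN(c2ccc(C3=NNC(c4ccc(N(C)C)cc4)C3)cc2)CC1`, in a functional assay on NCI-H1975 cells (Homo sapiens) for inhibition, read by sulforhodamine B assay, tested at 10 uM (a lower number here means less inhibition, a higher number more inhibition at the concentration tested (going by the name of the read-out)), compound 1 gives 2.4%
compound 2 `CN1CCN(c2ccc(C3=NN(C(=O)CCCl)C(c4ccc(N(C)C)cc4)C3)cc2)CC1`, in this assay compound 2 gives -0.2%

Compound 2 sits lowest of the two numbers, with compound 1 nearest; the step of a number 2.6 percentage points lower from compound 1 to compound 2 (within the scatter) is within the scatter, so nothing separates the two.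

Compound 3 `COC(=O)CC(=O)N1N=C(c2ccc(N3CCN(C)CC3)cc2)CC1c1ccc(N(C)C)cc1` awaits measurement. It differs from compound 2 by methoxycarbonyl in place of chloromethyl on a saturated chain carbon bound to a carbonyl carbon. Going by the values given here, the only measured step, a number 2.6 percentage points lower from compound 1 to compound 2 (within the scatter), changed the group on the ring nitrogen rather than the chain carbon bound to the carbonyl carbon, so it bears on the new change only loosely; it was within the scatter, and both measured compounds sit near zero.

No step beyond the scatter is therefore expected in this assay; compound 3 is estimated at 1%, between -10% and 12%, which means an expected step of a number 1.2 percentage points higher from compound 2 to compound 3 (within the scatter).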

Compound 3, a percentage reported as inhibition, at one concentration (the size of the read-out at that concentration, not a potency): -2.2%
For compound 3 the middle estimate is 3.2 percentage points above the measured one; the measured number falls inside the stated range.
By their numbers in this assay, from the lowest: compounds 3, 2 and 1 (each within the scatter of the next).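

In this assay, methoxycarbonyl in place of chloromethyl on a saturated chain carbon bound to a carbonyl carbon gives a number 2 percentage points lower from compound 2 to compound 3 (within the scatter), so this first change at the chain carbon separates nothing, and the chlorine-bearing chain and the ester-bearing chain cannot be told apart here. ((Methoxycarbonyl)methyl)carbonyl in place of hydrogen on an amine nitrogen in a ring gives a number 4.6 percentage points lower from compound 1 to compound 3 (within the scatter), so a second group on that ring nitrogen also leaves the number within the scatter of the core of compound 1. Nothing available bears on why these three compounds read alike.

Still open, going by these compounds, is whether any group on this chain carbon, such as an amine or a carboxylic acid, would shift the number in this assay. A longer chain on the carbonyl is equally untested by the compounds shown here.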